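Oxazole ketone series: dimethylcarbamoyl to cyanopyridyl at the ring

The source may hold more compounds than are shown below. What is called first, only, known or untested is meant among the compounds shown, and "the series" means these compounds.

Measured so far:
- compound 1 `COC(=O)c1cnc(C(=O)CCc2ccc(COc3ccccc3)cc2)o1`: 1.6 nM
- compound 2 `N#Cc1cccc(-c2cnc(C(=O)CCc3ccc(-c4ccccc4)cc3)o2)n1`: 2.9 nM
- compound 3 `CN(C)C(=O)c1cnc(C(=O)CCc2ccc(COc3ccccc3)cc2)o1`: 6.7 nM

In an assay for inhibition of Fatty-acid amide hydrolase 1 (Rattus norvegicus) (a lower number here means a stronger inhibitor, a higher number a weaker inhibitor), compound 3 gives the highest number of the three. The one step that connects two of these compounds, a 4.2-fold higher number from compound 1 to compound 3 (0.62 log units; beyond the scatter), shows that the group on the carbonyl carbon at this end of the core moves the number by a modest but clear amount.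

Compound 4 `N#Cc1cccc(-c2cnc(C(=O)CCc3ccc(COc4ccccc4)cc3)o2)n1` is the next compound, not yet measured. Relative to compound 3 the change is 6-cyanopyridin-2-yl in place of dimethylcarbamoyl on an aromatic carbon. Among the compounds with values here, no measured step covers this exchange directly. The only point of reference for the entering group is compound 2, which carries a 6-cyanopyridin-2-yl group on the same ring with a different tail, and which in this assay gives 2.9 nM, a lower number than compound 3 but a higher one than compound 1. The measured step from compound 1 to compound 3 does not bear on the entering group; it only shows that this position tolerates exchange with modest consequence.

The expectation for compound 4 is therefore a step of a 2.7-fold lower number from compound 3 to compound 4 (0.43 log units; beyond the scatter), downward, of modest size. Compound 4 is estimated at 2.5 nM, with a range from 0.8 nM to 8 nM.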

Compound 4, inhibition constant: 0.56 nM
Compound 4: middle estimate off by 4.5-fold (0.65 log units), on the high side; the measured number lies below the stated range.
By their numbers in this assay, from the lowest: compound 4; then compounds 1 and 2 (each within the scatter of the next); then compound 3.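

In this assay, the 6-cyanopyridin-2-yl group can now be compared directly with both carbonyl groups at this position on the shared core: replacing dimethylcarbamoyl gives a 12-fold lower number from compound 3 to compound 4 (1.08 log units; beyond the scatter) and replacing methoxycarbonyl gives a 2.9-fold lower number from compound 1 to compound 4 (0.46 log units; beyond the scatter), so with the phenoxymethyl tail held fixed, the entering group gives the lowest number of the three. The tail also matters with this group in place, since phenoxymethyl in place of phenyl gives a 5.2-fold lower number from compound 2 to compound 4 (0.71 log units; beyond the scatter), and the value of compound 2 alone therefore did not show how low the number could go with the phenoxymethyl tail. The exchange at this position is thus more than a tolerated one, and its large step against dimethylcarbamoyl shows that the choice of group here can shift the number well beyond the scatter.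

Still open, on these data alone, is how much of the result depends on the nitrile, which a plain pyridin-2-yl group at this position would test, and how a carboxylic acid there would rank against compound 4. Nothing available explains the size of these steps.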